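The source may report more compounds than this note shows. Statements on the series, on what has been measured and on what is new or still open speak of the compounds shown alone.

Of the compounds shown here, three have so far been measured in a physicochemical assay for solubility, in phosphate buffer, measured as kinetic solubility, with a stated time of 1 h, at pH 7.4; a lower number here means a less soluble compound, a higher number a more soluble compound. Compound 1 `Cc1cc(C)cc(NC(=O)COc2cc(C)nc3ccc(C)cc23)c1` gives 83000 nM, compound 2 `COc1ccc2nc(C)cc(OC(C)C(=O)Nc3cc(C)cc(C)c3)c2c1` gives 61000 nM, and compound 3 `COc1cccc(NC(=O)COc2cc(C)nc3ccc(OC)cc23)c1` gives 35000 nM. Compound 3 thus holds the lowest of the three numbers; its gap to compound 2 lies within the scatter of the measurement, while its gap to compound 1 lies beyond it, so compound 1 stands higher than compound 3 in this assay. No two of the measured compounds differ in a single place, so no single step can be read off among them.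

Compound 4 `COc1ccc2nc(C)cc(OCC(=O)Nc3cc(C)nc(C)n3)c2c1` has not yet been measured in this assay. Relative to compound 3 it carries 2,6-dimethylpyrimidin-4-yl in place of 3-methoxyphenyl on an amide-type nitrogen. The shared core and the linker to the amide remain as in compound 3. For the measured compounds named here, with no measured step of the same kind available, the size of the change can only be estimated. Compound 4 is expected to lie somewhat higher, by an estimated 1.4-fold higher number from compound 3 to compound 4 (0.15 log units; within the scatter), a step that may well stay within the scatter. The expected reading of compound 4 in this assay is 50000 nM, within a range from 20000 nM to 120000 nM.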

Compound 4, solubility: 5000 nM
For compound 4 the middle estimate is 10-fold (1.00 log units) above the measured one; measured number below the stated range.
By their numbers in this assay, from the lowest: compound 4; then compounds 3, 2 and 1 (each within the scatter of the next, the first and the last beyond it).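

In this assay, for the compounds shown here, 2,6-dimethylpyrimidin-4-yl in place of 3-methoxyphenyl on an amide-type nitrogen gives a 7.0-fold lower number from compound 3 to compound 4 (0.85 log units; beyond the scatter), the first single-place change to be read in this set. It shows that the read-out responds to the group at this position, with the shared core and the linker to the amide held as in compound 3, even though both groups have 8 heavy atoms and no net charge. No measurement is at hand that accounts for the size of this step.

On these data alone, it remains open whether the step follows the 2 hetero atoms of the entering ring or its methyl groups. As far as these compounds go, it is also open how an amine or a carboxylic acid on the ring at this position would compare.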